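A few compounds are considered here, and "the series" means these few. Any claim that something is new, unique, unknown or untested is made for them only; others in the source may bear on it.

Measured compounds:
- compound 1, `O=C(O)CCNC(=O)c1ccc(CC(c2ccc(OC(F)(F)F)cc2)c2nc(-c3ccc(Cl)cc3)cs2)cc1`, gives 98 nM in an in vitro assay on BHK cells for displacement of a labelled ligand from Glucagon receptor (Homo sapiens), read by scintillation proximity assay; a lower number here means a stronger inhibitor, a higher number a weaker inhibitor
- compound 2, `O=C(O)CCNC(=O)c1ccc(CC(c2ccc(Cl)cc2)c2nc(-c3ccc(C(F)(F)F)cc3)cs2)cc1`, gives 96 nM in this assay
- compound 3, `O=C(O)CCNC(=O)c1ccc(CN(c2ccc(Cl)cc2)c2nc(-c3ccc(C(F)(F)F)cc3)cs2)cc1`, gives 76 nM in this assay

All three compounds share a common core that carries an acid-bearing amide on one end and a thiazole bearing a substituted phenyl on the other. Compound 2 stands second highest of the three numbers, but its value sits within the scatter of both compound 1 and compound 3, so the three are indistinguishable on these data.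

Compound 4, `O=C(O)CCNC(=O)c1ccc(CC(c2ccc(Cl)cc2)c2nc(-c3ccc(OC(F)(F)F)cc3)cs2)cc1`, has not yet been measured. It differs from compound 2 in one place: trifluoromethoxy in place of trifluoromethyl on an aromatic carbon, on an aromatic carbon of a six-membered aromatic ring of carbon only. Compound 1 already carries a trifluoromethoxy group, though on the other phenyl, and its value in this assay matches compound 2 within the scatter. Among the compounds with values here, with no measured pair showing this exact change, no step beyond the scatter is expected in either direction in this assay.

Compound 4 is therefore estimated at 90 nM, with a range from 40 nM to 200 nM, which means an expected step of a 1.1-fold lower number from compound 2 to compound 4 (0.03 log units; within the scatter).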

Compound 4, half-maximal inhibitory concentration: 153 nM
Beside the measured number, compound 4's estimate is 1.7-fold (0.23 log units) below it, within the range that was stated.
By their numbers in this assay, from the lowest: compounds 3, 2, 1 and 4 (each within the scatter of the next).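

Within the data shown here, this pair is the first in the set to differ in one place only, which gives a direct reading of trifluoromethoxy in place of trifluoromethyl on an aromatic carbon, para to a large group. In this assay the change gives a 1.6-fold higher number from compound 2 to compound 4 (0.20 log units; within the scatter) and so does not separate the two compounds. At this position, then, the larger group, which adds an oxygen and one hydrogen-bond acceptor by the count, leaves a result that cannot be told apart from the ordinary spread of repeated measurements, and no supporting data bear on this result.

The compounds shown leave open whether this position would accept a group of a different kind in place of trifluoromethyl, such as an amine, a carboxylic acid or a longer alkyl chain, which could show how much change it takes to produce a step beyond the scatter. Also open, as far as these compounds go, is whether the same exchange of trifluoromethyl for trifluoromethoxy would give a step of similar size on a different ring or with a different core.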